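The source may report more compounds than this note shows. Statements on the series, on what has been measured and on what is new or still open speak of the compounds shown alone.

Of the compounds shown here, three from this series have been tested in a functional assay on L1210 cells (Mus musculus) for antiproliferative activity, read by MTT assay, with a stated time of 2 days; on this read-out higher numbers stand for weaker inhibition and lower numbers for stronger inhibition. Compound 1 `CCCCC#Cc1cn(C/C=C/CN2C(=O)c3ccccc3C2=O)c(=O)[nH]c1=O` gives 236000 nM. Compound 2 `O=C1c2ccccc2C(=O)N1C/C=C/Cn1cc(C#CCCc2ccccc2)c(=O)[nH]c1=O` gives 44000 nM, and compound 3 `CCCCCc1ccc(C#Cc2cn(C/C=C/CN3C(=O)c4ccccc4C3=O)c(=O)[nH]c2=O)cc1` gives 39000 nM. Among these three numbers compound 3 has the lowest, though its gap to compound 2 is within the scatter, so the two cannot be placed in order; the step of a 6.1-fold lower number from compound 1 to compound 3 (0.78 log units; beyond the scatter) and the step of a 5.4-fold lower number from compound 1 to compound 2 (0.73 log units; beyond the scatter) set both apart from compound 1.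

Compound 4 `CCCCCCCCC#Cc1cn(C/C=C/CN2C(=O)c3ccccc3C2=O)c(=O)[nH]c1=O` has not yet been measured in this assay. It differs from compound 3 in one place: octyl in place of 4-pentylphenyl on a triple-bonded carbon. The step that bears most directly on this change is a 6.1-fold lower number from compound 1 to compound 3 (0.78 log units; beyond the scatter), in which a chain on the triple-bonded carbon was replaced by 4-pentylphenyl; the change to compound 4 runs the other way, back to a chain, although a longer one than the butyl of compound 1. The step of a 1.1-fold lower number from compound 2 to compound 3 (0.05 log units; within the scatter) shows that two rather different groups on that carbon can give the same number, which tempers any firm expectation. On balance the number for compound 4 is expected to rise, with the estimated step of a 2.6-fold higher number from compound 3 to compound 4 (0.41 log units; beyond the scatter), though the longer octyl chain may not return it fully to where compound 1 stands.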

Compound 4, half-maximal inhibitory concentration: > 250000 nM
Compound 4 was reported as a limit; the forecaster's own chance of this, stated with the estimate: 5%; middle value at least 2.5-fold (0.39 log units) away from the limit.
By their numbers in this assay, from the lowest: compounds 3 and 2 (each within the scatter of the next); then compound 1. At a limit, above all of these: compound 4.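

In this assay compound 4 is reported as a limit and not as a number: the limit of > 250000 nM in this assay, at which 1 of the 4 values shown sits. Even so, the steps of an at least 6.4-fold higher number from compound 3 to compound 4 (0.80 log units; beyond the scatter) and an at least 5.6-fold higher number from compound 2 to compound 4 (0.75 log units; beyond the scatter) can be read and together set the octyl chain on this triple-bonded carbon clearly apart from the two substituents that carry a six-membered aromatic ring. The third step of an at least 1.0-fold higher number from compound 1 to compound 4 (0.02 log units; that floor lies within the scatter) cannot be read, as its floor lies within the scatter, so the longer chain shows no sign of the lowering seen with the ring-bearing groups, and among the four compounds shown none goes against this division.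

The compounds shown leave open whether the aromatic ring itself matters or whether another ring, such as cyclohexyl, on the triple-bonded carbon would give the same numbers as compound 2 and compound 3. They also leave open how a plain phenyl, or a chain ending in an amine or a carboxylic acid, would stand in this position, and how far compound 4 really lies from compound 1.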